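One Fluoro Substituent Tested Across Two Cores

The source may hold more compounds than are shown below. What is called first, only, known or untested is meant among the compounds shown, and "the series" means these compounds.

Measured compounds:
- compound 1, `C/C1=C\CC[C@@]2(C)O[C@@H]2[C@H]2OC(=O)[C@@H](CN3CCN(c4ccccc4)CC3)[C@@H]2C[C@H]1O`: 22000 nM
- compound 2, `C/C1=C\CC[C@@]2(C)O[C@@H]2[C@H]2OC(=O)[C@@H](CN3CCN(c4ccccc4F)CC3)[C@@H]2C[C@H]1O`: 25000 nM
- compound 3, `C[C@]12O[C@@H]1CC[C@@]1(C)O[C@@H]1[C@H]1OC(=O)[C@@H](CN3CCN(c4ccccc4)CC3)[C@@H]1C[C@H]2O`: 31000 nM

All three were tested in a functional assay on Hs 683 cells (Homo sapiens) for inhibition, read by colorimetric assay and MTT assay, with a stated time of 72 h; on this read-out lower numbers stand for stronger inhibition and higher numbers for weaker inhibition. Compound 1 gives 22000 nM, compound 2 gives 25000 nM and compound 3 gives 31000 nM. The three numbers sit close together, and no ordering among them can be claimed.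

Compound 1 and compound 2 share a core and differ in one place:

fluoro in place of hydrogen on an aromatic carbon

This change made a step of a 1.1-fold higher number from compound 1 to compound 2 (0.06 log units; within the scatter), which is within the scatter.

Compound 3 carries a different core; the difference between the two cores is not broken down here. Compound 4, `C[C@]12O[C@@H]1CC[C@@]1(C)O[C@@H]1[C@H]1OC(=O)[C@@H](CN3CCN(c4ccccc4F)CC3)[C@@H]1C[C@H]2O`, is the unmeasured partner of compound 3, and it differs from compound 3 in this way:

fluoro in place of hydrogen on an aromatic carbon

The place of this change is described in the same words as for compound 1 and compound 2, so it is the same change, now made on the core of compound 3.

Because the earlier instance gave only a 1.1-fold higher number from compound 1 to compound 2 (0.06 log units; within the scatter), the step from compound 3 to compound 4 is expected to be small as well, about a 1.1-fold higher number from compound 3 to compound 4 (0.04 log units; within the scatter). Compound 4 is therefore estimated at 34000 nM in this assay, with a likely range from 17000 nM to 70000 nM. This estimate rests on a single earlier instance of the change and on the value of compound 3, so it carries the usual uncertainty of such a transfer.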

Compound 4, half-maximal inhibitory concentration: 18000 nM
For compound 4 the middle estimate is 1.9-fold (0.28 log units) above the measured one; the range from low to high includes it.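

In this assay, the change from phenyl to 2-fluorophenyl on the second core gives a 1.7-fold lower number from compound 3 to compound 4 (0.24 log units; within the scatter), so this step, like the first, is too small to be told apart from the ordinary variation between repeated measurements. Set side by side, the two instances of the change agree as closely as this read-out can show: the same change on two cores in this assay, a 1.1-fold higher number (0.06 log units; within the scatter) from compound 1 to compound 2 and a 1.7-fold lower number (0.24 log units; within the scatter) from compound 3 to compound 4, 2.0-fold (0.29 log units) apart, within the scatter of two such steps. Going by these compounds alone, in this series, then, the change can be carried from one core to the other without any step that stands out from the scatter on either core, but this rests on only two pairs of compounds and does not show that the change has truly no effect or that the two cores respond identically, as a small real difference would go unseen here.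

Every compound shown carries either phenyl or 2-fluorophenyl on the piperazine nitrogen, and it remains open whether a different group on that ring, such as a chlorine atom, a methoxy group or a carboxylic acid, would produce a step beyond the scatter on either core. As far as these compounds go, it also remains open whether the two cores would still agree for such a group, since a larger step would test the transfer far more strictly than these two small ones can.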